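Difluorination of the sulfonyl aryl ring in a quinoline sulfone series

This account rests on a few compounds, and the source may have more. Where it says the series, first, only, none or still open, it means among the compounds named here.

Of the compounds shown here, three with a shared core have been measured in an assay on isolated protein for displacement of a labelled ligand from metabotropic glutamate receptor 5 (Homo sapiens), with a stated time of 60 min, tested at 1 uM; a lower number here means less inhibition, a higher number more inhibition at the concentration tested (going by the name of the read-out). Compound 1 `Cc1ccc(S(=O)(=O)c2cnc3cc(F)ccc3c2N2CCC(C)CC2)cc1C` gives 90%, compound 2 `COCC1CCN(c2c(S(=O)(=O)c3cc(F)cc(F)c3)cnc3cc(F)ccc23)CC1` gives 83%, and compound 3 `CC1CCN(c2c(S(=O)(=O)c3ccccc3)cnc3cc(F)ccc23)CC1` gives 87%. Compound 3 thus stands second of the three numbers; its nearest neighbour is compound 1, and the step of a number 3 percentage points lower from compound 1 to compound 3 (within the scatter) lies within the scatter, so no order between them is claimed. Compound 2 is furthest from compound 3, yet that gap also lies within the scatter.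

The next compound, compound 4 `CC1CCN(c2c(S(=O)(=O)c3cc(F)cc(F)c3)cnc3cc(F)ccc23)CC1`, differs from compound 3 in one place: 3,5-difluorophenyl in place of phenyl on a sulfonyl sulfur. Among the compounds with values here, the only measured step at the same place, a number 3 percentage points lower from compound 1 to compound 3 (within the scatter), shows that exchanging one aryl group on the sulfonyl sulfur for another left this assay essentially unchanged. Compound 2, which carries the same 3,5-difluorophenyl group, also differs elsewhere, so its value can only be read alongside that of compound 3, and both sit close together.

On this basis a step of a number 2 percentage points lower from compound 3 to compound 4 (within the scatter) that stays within the scatter is expected, and compound 4 is estimated at 85% in this assay, with a likely range from 74% to 94%.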

Compound 4, a percentage reported as inhibition, at one concentration (the size of the read-out at that concentration, not a potency): 77%
Beside the measured number, compound 4's estimate is 8 percentage points above it, and the stated range covers the measured number.
By their numbers in this assay, from the lowest: compounds 4, 2, 3 and 1 (each within the scatter of the next, the first and the last beyond it).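

In this assay, putting 3,5-difluorophenyl in place of phenyl on a sulfonyl sulfur gives a number 10 percentage points lower from compound 3 to compound 4 (within the scatter), so this exchange taken alone cannot be told apart from the usual spread of repeat measurements. The same place does yield a step that can be read: 3,5-difluorophenyl in place of 3,4-dimethylphenyl gives a number 13 percentage points lower from compound 1 to compound 4 (beyond the scatter), a modest difference, whereas the earlier exchange of phenyl for 3,4-dimethylphenyl, a number 3 percentage points lower from compound 1 to compound 3 (within the scatter), could not be read, so the choice of aryl group on the sulfonyl sulfur is now seen to matter to a small degree in one pair. With 3,5-difluorophenyl held in place, hydrogen in place of methoxy on a saturated chain carbon bound to a saturated ring carbon gives a number 6 percentage points lower from compound 2 to compound 4 (within the scatter), so no difference can be claimed for that change.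

Nothing available bears on why these aryl groups differ in this assay. From the compounds shown here alone, whether a pyridyl or a cyclohexyl group on the sulfonyl sulfur would give a number like those of the three aryl groups here remains open, as does whether a single fluorine on the phenyl ring would already move the number.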